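The compounds below may be only part of what the source reports. "The series", "measured", "known", "first", "only" and "open" are said of these compounds alone.

Of the compounds shown here, three have been measured in a functional assay on K562 cells (Homo sapiens) for cytotoxicity, read by trypan blue exclusion, with a stated time of 96 h; on this read-out higher numbers stand for weaker inhibition and lower numbers for stronger inhibition. Compound 1 `COc1ccc(CS(=O)(=O)/C=C/c2c(OC)cccc2OC)cc1[N+](=O)[O-]` gives 20000 nM, compound 3 `COc1cc(OC)c(/C=C/S(=O)(=O)Cc2ccc(Br)c([N+](=O)[O-])c2)c(OC)c1` gives 25000 nM, and compound 2 `COc1cc(OC)c(/C=C/S(=O)(=O)Cc2ccc(OC)c([N+](=O)[O-])c2)c(OC)c1` gives 2500 nM, the lowest of the three numbers. Its gaps to the other two lie beyond the scatter, so compound 2 is the most potent of this small set and a sensible reference point.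

Compound 4 `COC(=O)C(F)(F)Nc1cc(CS(=O)(=O)/C=C/c2c(OC)cc(OC)cc2OC)ccc1OC` has not yet been measured. Compared with compound 2, it carries one structural change: (difluoro(methoxycarbonyl)methyl)amino in place of nitro on an aromatic carbon. In words, this is (difluoro(methoxycarbonyl)methyl)amino in place of nitro on an aromatic carbon, ortho to a methoxy group.

Two measured steps offer some guidance. Methoxy in place of hydrogen gave an 8.0-fold lower number from compound 1 to compound 2 (0.90 log units; beyond the scatter), while bromo in place of methoxy gave a 10-fold higher number from compound 2 to compound 3 (1.00 log units; beyond the scatter). Neither step replaces the nitro group, so they suggest a scale but no direction. A step of similar size is therefore expected here. A lean toward a lower number is only a judgement, and a higher number remains possible. The expected change is a 6.3-fold lower number from compound 2 to compound 4 (0.80 log units; beyond the scatter). For compound 4 the estimated value is 400 nM, with an expected range from 40 nM to 4000 nM.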

Compound 4, half-maximal inhibitory concentration: 250 nM
Compound 4: middle estimate off by 1.6-fold (0.20 log units), on the high side, within the range that was stated.
By their numbers in this assay, from the lowest: compound 4; then compound 2; then compounds 1 and 3 (each within the scatter of the next).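

In this assay, the nitro group of compound 2 proves not to be needed at this position, ortho to a methoxy group: putting (difluoro(methoxycarbonyl)methyl)amino there gives a 10-fold lower number from compound 2 to compound 4 (1.00 log units; beyond the scatter). Going by these compounds alone, the earlier steps all kept the nitro group and changed other places on the shared core, so this is the first evidence on the position itself, and it shows that a larger group, with 8 heavy atoms against 3 and with 1 hydrogen-bond donor where nitro has 0, is compatible with a stronger result in this cell assay. No measurement shown here explains why the number falls.

The entering group differs from nitro in several ways at once, so this single step cannot separate the contributions of its amino nitrogen, its two fluorines and its methoxycarbonyl part. From the compounds shown here alone, a plain amine at the same position, or a carboxylic acid in place of the methyl ester, would be the kind of neighbour needed to tell which part of the group goes with the lower number, and how either would read remains open.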